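The source may hold more compounds than are shown below. What is called first, only, known or untested is meant among the compounds shown, and "the series" means these compounds.

Compound 1 `CCn1c(C(=O)N(CCC#N)CCC#N)ccc1C(CC)(CC)c1ccc(OCCC(O)(CC)CC)c(C)c1` gives 37800 nM in an ADME assay on L02 cells (Homo sapiens) for antiproliferative activity, read by MTT assay, with a stated time of 48 h; on this read-out lower numbers stand for stronger inhibition and higher numbers for weaker inhibition. Compound 2 `C=CCN(C)C(=O)c1ccc(C(CC)(CC)c2ccc(OCCC(O)(CC)CC)c(C)c2)n1CC` gives 1190 nM. Compound 3 `CCC(C)C(NC(=O)c1ccc(C(CC)(CC)c2ccc(OCCC(O)(CC)CC)c(C)c2)n1CC)C(=O)O` gives 9990 nM.

Among these three, compound 2 has the lowest number; the nearest is an 8.4-fold higher number from compound 2 to compound 3 (0.92 log units; beyond the scatter) and the furthest is a 32-fold lower number from compound 1 to compound 2 (1.50 log units; beyond the scatter). Compound 4 `CCn1c(C(=O)NC(CC(=O)O)C(=O)OC)ccc1C(CC)(CC)c1ccc(OCCC(O)(CC)CC)c(C)c1` has not yet been measured in this assay. Relative to compound 2 the change is a group of 10 heavy atoms (5 carbon, 1 nitrogen, 4 oxygen; no ring) in place of a group of 5 heavy atoms (4 carbon, 1 nitrogen; no ring), on a carbonyl carbon. The step that bears on it runs from compound 2 to compound 3, where (1-carboxy-2-methylbutyl)amino replaced allyl(methyl)amino on the same carbonyl carbon and the number rose by an 8.4-fold higher number from compound 2 to compound 3 (0.92 log units; beyond the scatter). Compound 4 likewise exchanges allyl(methyl)amino for a larger amino-linked group on that carbon, so a rise of similar size is expected, an estimated step of a 7.6-fold higher number from compound 2 to compound 4 (0.88 log units; beyond the scatter). Compound 4 is therefore estimated at 9000 nM, with a range from 3000 nM to 30000 nM.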

Compound 4, half-maximal inhibitory concentration: 7590 nM
Compound 4: the middle estimate sits 1.2-fold (0.07 log units) above what was measured; measured number inside the range.
By their numbers in this assay, from the lowest: compound 2; then compounds 4 and 3 (each within the scatter of the next); then compound 1.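

At this carbonyl carbon in this assay, a second group in place of allyl(methyl)amino also raises the number (a 6.4-fold higher number from compound 2 to compound 4 (0.80 log units; beyond the scatter)), so the rise seen with compound 3 is not confined to that one group. Changing the chain on the amide-type nitrogen makes no clear difference (a 1.3-fold lower number from compound 3 to compound 4 (0.12 log units; within the scatter)), while compound 4 remains well apart from the dinitrile (a 5.0-fold lower number from compound 1 to compound 4 (0.70 log units; beyond the scatter)). No measurement at hand explains these differences. The compounds shown leave open how a ring on this carbonyl carbon, such as morpholine or piperidine, would compare with allyl(methyl)amino.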